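From Compound 3 to Compound 4: One Group Rearranged

The source may report more compounds than this note shows. Statements on the series, on what has been measured and on what is new or still open speak of the compounds shown alone.

Of the compounds shown here, three have been measured in an assay for inhibition of Amine oxidase [flavin-containing] A (Bos taurus), read by fluorescence, with a stated time of 60 min; a lower number here means a stronger inhibitor, a higher number a weaker inhibitor. Compound 1 `O=C(NNc1nc2ccccc2nc1Cc1ccccc1)c1ccc(Br)cc1` gives 74 nM, compound 2 `O=C(Cn1c(=O)c(Cc2ccccc2)nc2ccccc21)N/N=C/c1ccccc1` gives 3.1 nM, and compound 3 `COc1ccc(/C=N/NC(=O)Cn2c(=O)c(Cc3ccccc3)nc3ccccc32)cc1` gives 6.6 nM, the second-lowest number of the three, nearer to compound 2 than to compound 1. Compound 4 `C/C(=N\NC(=O)Cn1c(=O)c(Cc2ccccc2)nc2ccccc21)c1ccc(O)cc1` has not yet been measured. It differs from compound 3 by a group of 10 heavy atoms (8 carbon, 1 nitrogen, 1 oxygen; one six-membered aromatic ring of carbon only) in place of a group of 10 heavy atoms (8 carbon, 1 nitrogen, 1 oxygen; one six-membered aromatic ring of carbon only), on an amide-type nitrogen. Going by the values given here, only one measured step touches this part of the molecule: a 2.1-fold higher number from compound 2 to compound 3 (0.33 log units; beyond the scatter), a modest weakening from adding a methoxy group. Among the compounds with values here, no measured pair shows the rearrangement itself, so the change is largely untested. The expectation is a step of a 1.2-fold higher number from compound 3 to compound 4 (0.08 log units; within the scatter), barely beyond the scatter. Compound 4 is therefore estimated at 8 nM, with a likely range from 2.5 nM to 25 nM.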

Compound 4, half-maximal inhibitory concentration: 1.6 nM
For compound 4 the middle estimate is 5.0-fold (0.70 log units) above the measured one; measured number outside the range, below it.
By their numbers in this assay, from the lowest: compounds 4 and 2 (each within the scatter of the next); then compound 3; then compound 1.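

Rearranging the same atoms on the amide-type nitrogen changes the result (a 4.1-fold lower number from compound 3 to compound 4 (0.62 log units; beyond the scatter)), so this position responds to how the group is built, not only to which atoms it holds. The larger group of compound 4 and the smaller group of compound 2 cannot be told apart (a 1.9-fold lower number from compound 2 to compound 4 (0.29 log units; within the scatter)), so the extra atoms bring no clear change here. No evidence on the reason for these results is available.

Going by these compounds, compound 4 gains a hydroxyl and a methyl together as it loses the methoxy, so which of these changes matters remains open. On these data alone, how an amine or a carboxylic acid on that aromatic ring would read is also open.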